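The source may hold more compounds than are shown below. What is called first, only, known or untested is meant among the compounds shown, and "the series" means these compounds.

Measured so far:
compound 1, `CC(/C=N/Nc1ccc([N+](=O)[O-])cc1)=N\NC(=O)c1ccccc1Nc1ccccc1` — in a functional assay on cells (Splenocyte, Mus musculus, strain BALB/c) for inhibition, read by scintillation counting and thymidine incorporation, with a stated time of 72 h (on this read-out lower numbers stand for stronger inhibition and higher numbers for weaker inhibition), compound 1 gives "not determined" (no result reported);
compound 2, `CC(/C=N/Nc1ccc([N+](=O)[O-])cc1)=N\NC(=O)c1ccc(N)cc1` — in this assay compound 2 gives only a limit, > 12000 nM;
compound 3, `CC(/C=N/Nc1ccc([N+](=O)[O-])cc1)=N\NC(=O)c1ccc(O)cc1` — in this assay compound 3 gives 1510 nM.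

Compound 1 therefore stands nowhere on the numbers: for it this assay reports nothing, and the remaining value in the set is not a number but a limit, (the limit of > 12000 nM in this assay, at which 1 of the 3 values shown sits). Within the data shown here, the one measured step, an at least 7.9-fold lower number from compound 2 to compound 3 (0.90 log units; beyond the scatter), concerns a substituent on the benzamide ring and is a different change from the one leading to compound 4, `CC(/C=N/Nc1ccc([N+](=O)[O-])cc1)=N\NC(=O)c1ccccc1Oc1ccccc1`, which is phenoxy in place of anilino on an aromatic carbon. Among the measured compounds shown here, no measured step bears on that change, and compound 1 itself has no value to step from, so neither the direction nor the size of the move in this assay can be read from the data. The expectation for compound 4 rests only on where the measured members of the series fall: the estimate is 5000 nM, with a range from 1000 nM to 25000 nM.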

Compound 4, half-maximal inhibitory concentration: > 12000 nM
Compound 4 ended at the assay's limit (the forecaster's own chance of this, stated with the estimate: 40%); middle value at least 2.4-fold (0.38 log units) away from the limit.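

In this assay compound 4 gives > 12000 nM, which is a limit and not a number. Among these compounds, compound 1 gives "not determined" (no result reported), so no step between these two compounds can be read. The compounds shown leave open whether phenoxy in place of anilino changes inhibition in this assay at all.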